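Swapping benzyl for trifluoromethyl on the shared core

A few compounds are considered here, and "the series" means these few. Any claim that something is new, unique, unknown or untested is made for them only; others in the source may bear on it.

Measured so far in a functional assay on DU-145 cells (Homo sapiens) for cytotoxicity, read by MTT assay; on this read-out higher numbers stand for weaker inhibition and lower numbers for stronger inhibition:
compound 1 `c1ccc(Cc2nnc(-c3c[nH]c4ccccc34)o2)cc1` gives > 1000000 nM, a limit of the assay.
compound 2 `COc1ccc(-c2nnc(-c3c[nH]c4ccccc34)o2)c(OC)c1OC` gives > 1000000 nM, a limit of the assay.
compound 3 `COc1cc(-c2nnc(-c3c[nH]c4ccccc34)o2)ccc1OCc1ccccc1` gives > 1000000 nM, a limit of the assay.

Compound 1 has no number of its own on this read-out; what stands for it is a limit, and the same is true of compound 2 and compound 3. Among the measured compounds shown here, the picture is summed up by the limit of > 1000000 nM in this assay, at which 3 of the 3 values shown sit, so no step between measured compounds can be read, and the three share only the fact that none of them reached a measurable inhibition.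

Compound 4 `FC(F)(F)c1nnc(-c2c[nH]c3ccccc23)o1` differs from compound 1 in one place: trifluoromethyl in place of benzyl on an aromatic carbon. For the measured compounds named here, nothing among the measured compounds shows what this exchange does, since every value is a limit and no change between two numbers has been seen.

With all three measured compounds sitting at the limit, compound 4 is expected to stay at or near that limit too, with a step from compound 1 of a step that the limit leaves unreadable from compound 1 to compound 4, that is, no change beyond the scatter is expected. The estimate for compound 4 in this assay is 1500000 nM, expected to lie between 300000 nM and 5000000 nM, most likely reported again only as a limit.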

Compound 4, half-maximal inhibitory concentration: > 1000000 nM
Compound 4 ended at the assay's limit (the forecaster's own chance of this, stated with the estimate: 80%); the middle value lies beyond the limit too.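

Among the compounds shown here, compound 1 and compound 4 both rest on limits of the assay rather than numbers, so trading benzyl for trifluoromethyl gives no step that can be read in this assay. All that can be reported is this: the limit of > 1000000 nM in this assay, at which 4 of the 4 values shown sit.

The compounds shown leave open whether any group on the shared core gives a measurable inhibition, and how benzyl and trifluoromethyl would compare if both gave numbers.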